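The source may report more compounds than this note shows. Statements on the series, on what has been measured and on what is new or still open speak of the compounds shown alone.

Working notes on the series.

Two compounds carry numbers in a functional assay for inhibition, with Homo sapiens as the target (on this read-out higher numbers stand for weaker inhibition and lower numbers for stronger inhibition), so far. Compound 1, with the structure `O=c1c(O)c(O)oc2ccc(Cl)cc12`, gives 780000 nM in this assay. Compound 2, with the structure `O=C1C(O)=C(O)OC2CCCCC12`, is reported in this assay only as a limit, > 4000000 nM, not as a number. Among the measured compounds shown here, the position of compound 2 is therefore described by the limit of > 4000000 nM in this assay, at which 1 of the 2 values shown sits, and no step between compound 1 and compound 2 is recorded; their two values stand side by side without a measured gap.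

Compound 3, with the structure `O=C1C(O)=C(O)OC2CCCC[C@H]12`, is the next compound to be measured in this assay. Its relation to compound 2 is the two compounds have the same atoms and bonds; at least one stereo element is drawn with a configuration in one of them and without one in the other: 1 of 2 stereo elements differ; a stereocentre at a saturated ring carbon is drawn without a configuration in compound 2 and S in compound 3: the two compounds have the same atoms and bonds, and the only drawn difference is a stereocentre at a saturated ring carbon, left without a configuration in compound 2 and drawn as S in compound 3.

Since compound 2 is known only as a limit and the atoms and bonds are unchanged, no step beyond the scatter is expected from compound 2 to compound 3, and the estimated step is a step that the limit leaves unreadable from compound 2 to compound 3. Compound 3 is accordingly expected to sit near 6000000 nM in this assay, within a range of 2000000 nM to 20000000 nM, and most likely to be reported again as a limit rather than as a number.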

Compound 3, half-maximal inhibitory concentration: > 4000000 nM
Compound 3: only a limit was reported; the forecaster's own chance of this, stated with the estimate: 80%; the middle value does not contradict the limit.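

In this assay compound 3 is reported only as a limit, > 4000000 nM. Compound 2 is likewise known only as a limit, so no step can be read between compound 2 and compound 3. The compounds shown leave open how strongly either one inhibits and whether the configuration at the saturated ring carbon matters for inhibition.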